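The compounds below may be only part of what the source reports. "The series", "measured", "known", "first", "only" and "open" are said of these compounds alone.

Measured compounds:
compound 1, `C[Se]/C(=N\C(=O)c1cc2ccccc2s1)NC(=O)c1cc2ccccc2s1`, 37200 nM
compound 2, `CS/C(=N\C(=O)c1sccc1Cl)NC(=O)c1sccc1Cl`, 24700 nM
compound 3, `CS/C(=N\C(=O)c1cc2ccccc2s1)NC(=O)c1cc2ccccc2s1`, 8580 nM

All three were measured in a functional assay on PC-3 cells (Homo sapiens) for cytotoxicity, read by MTT assay, with a stated time of 72 h; on this read-out higher numbers stand for weaker inhibition of growth and lower numbers for stronger inhibition of growth. Compound 3 gives 8580 nM, the lowest of the three numbers. Compound 1 differs from compound 3 in one place: a group of 2 heavy atoms (1 carbon, 1 selenium; no ring) in place of a group of 2 heavy atoms (1 carbon, 1 sulfur; no ring), on a carbon with a double bond to nitrogen. This change gives a 4.3-fold higher number from compound 3 to compound 1 (0.64 log units; beyond the scatter). Compound 2 gives 24700 nM, a value within the scatter of that of compound 1 and beyond the scatter of that of compound 3. The difference between the core of compound 2 and the core of compound 3 is not broken down here.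

Compound 4, `C[Se]/C(=N\C(=O)c1sccc1Cl)NC(=O)c1sccc1Cl`, has not been measured in this assay. It differs from compound 2 by the same change: a group of 2 heavy atoms (1 carbon, 1 selenium; no ring) in place of a group of 2 heavy atoms (1 carbon, 1 sulfur; no ring), on a carbon with a double bond to nitrogen. Among the four compounds this change occurs twice in all, and only one instance is measured, so the expectation for compound 4 rests on that single step and carries the added uncertainty of a different core. In this assay the step from compound 2 to compound 4 is expected to be about a 3.8-fold higher number from compound 2 to compound 4 (0.59 log units; beyond the scatter), because the same change gave a 4.3-fold higher number from compound 3 to compound 1 (0.64 log units; beyond the scatter). Compound 4 is therefore estimated at 95000 nM, likely between 38000 nM and 240000 nM.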

Compound 4, concentration for 50% growth inhibition: 970 nM
Compound 4: middle estimate off by 98-fold (1.99 log units), on the high side, and the stated range ends above it.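

In this assay, the same exchange of methylsulfanyl for the group of one carbon and one selenium gives a 25-fold lower number from compound 2 to compound 4 (1.41 log units; beyond the scatter), so on these two cores the change does not carry over in either direction or size: the same change on two cores in this assay, a 4.3-fold higher number (0.64 log units; beyond the scatter) from compound 3 to compound 1 and a 25-fold lower number (1.41 log units; beyond the scatter) from compound 2 to compound 4, 110-fold (2.04 log units) apart, beyond the scatter of two such steps

An effect measured for this change on the core of compound 3 therefore cannot be used as a guide to its effect on the core of compound 2, and the outcome of the exchange has to be read separately for each core. These two pairs do not show which feature of the cores accounts for the opposite outcomes, and they give no general rule for a further core.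

The compounds shown leave open which of the two outcomes, if either, would hold on a third core. They also leave open how a longer chain, such as ethyl, on the sulfur or selenium, or an amine on the carbon with a double bond to nitrogen, would behave on each core.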